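Swapping the oxazole isomer on the carbonyl of compound 1

The source may report more compounds than this note shows. Statements on the series, on what has been measured and on what is new or still open speak of the compounds shown alone.

The three measured compounds share one core, seen in compound 1 `COc1cc2nccc(Oc3ccc(NC(=O)c4ncc(-c5ccc(F)cc5)o4)cc3)c2cc1OC`. In a functional assay on PC-3 cells (Homo sapiens) for antiproliferative activity, read by MTT assay, with a stated time of 72 h (on this read-out higher numbers stand for weaker inhibition and lower numbers for stronger inhibition), compound 1 gives 21900 nM, the highest number of the three. Compound 2 `COc1cc2c(Oc3ccc(NC(=O)C4(c5nnc(-c6ccc(F)cc6)o5)CC4)cc3F)ccnc2cc1OCCCN1CCN(C)CC1` gives 1670 nM in this assay, and compound 3 `COc1cc2c(Oc3ccc(NC(=O)c4ncc(-c5ccc(F)cc5)o4)cc3)ccnc2cc1OCCCN1CCC(C)CC1` gives 720 nM. Among the measured compounds shown here, compound 2 differs from compound 1 in more than one place, so its value shows only that compound 2 sits at a lower number than compound 1. For the measured compounds named here, the single one-place step recorded is a 30-fold lower number from compound 1 to compound 3 (1.48 log units; beyond the scatter), a large change. It concerns a chain on the aromatic oxygen.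

Compound 4 `COc1cc2nccc(Oc3ccc(NC(=O)c4cc(-c5ccc(F)cc5)on4)cc3)c2cc1OC` keeps everything of compound 1 except the ring on the carbonyl carbon: 5-(4-fluorophenyl)-1,2-oxazol-3-yl in place of 5-(4-fluorophenyl)-1,3-oxazol-2-yl on a carbonyl carbon. Going by the values given here, no measured step touches this ring. The step from compound 1 to compound 3 concerns a different position, and compound 2 carries a different ring together with other changes, so neither gives a guide to the size or direction of this change. With nothing pointing either way, the expected step in this assay is one no larger than the scatter: a 1.1-fold lower number from compound 1 to compound 4 (0.04 log units; within the scatter). Compound 4 is therefore estimated at 20000 nM, with a range from 7000 nM to 55000 nM.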

Compound 4, half-maximal inhibitory concentration: 29400 nM
Beside the measured number, compound 4's estimate is 1.5-fold (0.17 log units) below it; measured number inside the range.
By their numbers in this assay, from the lowest: compound 3; then compound 2; then compounds 1 and 4 (each within the scatter of the next).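

In this assay, the swap of 5-(4-fluorophenyl)-1,2-oxazol-3-yl for 5-(4-fluorophenyl)-1,3-oxazol-2-yl on a carbonyl carbon gives a 1.3-fold higher number from compound 1 to compound 4 (0.13 log units; within the scatter), so the two compounds cannot be told apart in this assay. Among the compounds shown here, this is the first measured step at this position, and it shows that, on the core of compound 1, rearranging the atoms of this ring while keeping the same atoms and the same counts of rings, donors and acceptors leaves the number within the scatter. Nothing available explains this outcome or says what either ring does in the cells.

The compounds shown leave open whether the same swap would also stay within the scatter on compound 3, which carries the 2-(4-methylpiperidin-1-yl)ethyl chain and has a far lower number than compound 1. They also leave open how far this position tolerates a larger change, such as a thiazole in place of the oxazole ring, or an amine or a carboxylic acid in place of the fluorine on the phenyl ring.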